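The source may hold more compounds than are shown below. What is called first, only, known or untested is meant among the compounds shown, and "the series" means these compounds.

Compound 3 `CCN(CC)CCNC(=O)Nc1nc2ccc(-c3cnc(OC)c(NS(=O)(=O)c4ccc(C)cc4)c3)cc2s1` is the starting point of this step. In a functional assay on MCF7 cells (Homo sapiens) for antiproliferative activity, read by MTT assay, with a stated time of 72 h (a higher number here means a weaker inhibitor, a lower number a stronger inhibitor), compound 3 gives 170 nM, the lowest of the two numbers recorded in this series. Compound 1 `COc1ncc(-c2ccc3nc(NC(=O)NCCN4CCCCC4)sc3c2)cc1NS(=O)(=O)c1ccc(F)cc1`, the nearest of the others, gives 450 nM in this assay, a gap from compound 3 that lies beyond the usual scatter. Compound 2 `CCCNc1nc2ccc(-c3cnc(Cl)c(NS(=O)(=O)c4ccc(F)cc4)c3)cc2s1` has no result in this assay, recorded as "not determined" (no result reported), so it offers no comparison.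

Compound 4 `CCN(CC)CCNC(=O)Nc1nc2ccc(-c3cnc(OC)c(NS(=O)(=O)c4ccc(F)cc4)c3)cc2s1` differs from compound 3 in a single place: fluoro in place of methyl on an aromatic carbon. For the measured compounds named here, no pair of measured compounds differing only in this way is at hand, so the size of the step cannot be read from earlier data; fluoro in place of methyl on an aromatic carbon, para to a large group, changes one heavy atom for another and neither adds nor removes a donor or acceptor. The step from compound 3 to compound 4 in this assay is expected to be small, a 1.2-fold higher number from compound 3 to compound 4 (0.09 log units; within the scatter), probably not beyond the scatter in either direction. Compound 4 is therefore estimated to give 210 nM in this assay, within a range from 90 nM to 480 nM.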

Compound 4, half-maximal inhibitory concentration: 320 nM
Compound 4: the middle estimate sits 1.5-fold (0.18 log units) below what was measured, within the range that was stated.
By their numbers in this assay, from the lowest: compounds 3, 4 and 1 (each within the scatter of the next, the first and the last beyond it).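

In this assay, 4-fluorophenyl in place of 4-methylphenyl on the sulfonyl group gives a 1.9-fold higher number from compound 3 to compound 4 (0.27 log units; within the scatter) and so does not separate these two groups at this position. For the compounds shown here, compound 4 also provides the first pair that differs only in the amine on the saturated chain, and diethylamino in place of piperidin-1-yl gives a 1.4-fold lower number from compound 1 to compound 4 (0.15 log units; within the scatter), so this exchange too leaves no readable difference. No measured property bears on either step, so the data offer no explanation for these results.

Going by these compounds, it remains open whether a methoxy or trifluoromethyl group in place of the fluoro would move the number beyond the scatter. On these data alone, it also remains open whether morpholin-4-yl or a longer chain in place of diethylamino would do so.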